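A few compounds are considered here, and "the series" means these few. Any claim that something is new, unique, unknown or untested is made for them only; others in the source may bear on it.

In a functional assay on LOX IMVI cells (Homo sapiens) for inhibition, read by sulforhodamine B assay, with a stated time of 48 h (a higher number here means a weaker inhibitor of growth, a lower number a stronger inhibitor of growth), compound 1 `O=C(Cc1csc2nc(-c3ccc(Br)cc3)cn12)N/N=C/c1ccc(O)cc1` gives 26300 nM. The only other measured relative, compound 2 `COc1cccc(OC)c1/C=N/NC(=O)Cc1csc2nc(-c3ccc(Br)cc3)cn12`, gives 47900 nM, and the two values lie within the usual scatter of each other. Compound 3 `O=C(Cc1csc2nc(-c3ccc(Br)cc3)cn12)N/N=C/c1ccc(Cl)cc1Cl` differs from compound 1 by one change, 2,4-dichlorophenyl in place of 4-hydroxyphenyl on a carbon with a double bond to nitrogen. Going by the values given here, the one measured step at this place, a 1.8-fold higher number from compound 1 to compound 2 (0.26 log units; within the scatter), stayed within the scatter, so no step beyond the scatter is expected here. The estimated step runs a 1.1-fold higher number from compound 1 to compound 3 (0.06 log units; within the scatter). The expected value for compound 3 is 30000 nM, with an estimated range of 12000 nM to 70000 nM.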

Compound 3, concentration for total growth inhibition: 49000 nM
Estimate against measurement, compound 3: 1.6-fold (0.21 log units) below, within the range that was stated.
By their numbers in this assay, from the lowest: compounds 1, 2 and 3 (each within the scatter of the next).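

Putting 2,4-dichlorophenyl in place of 4-hydroxyphenyl gives a 1.9-fold higher number from compound 1 to compound 3 (0.27 log units; within the scatter) and putting it in place of 2,6-dimethoxyphenyl gives a 1.0-fold higher number from compound 2 to compound 3 (0.01 log units; within the scatter) in this assay on this carbon with a double bond to nitrogen. The three aromatic rings therefore cannot be told apart here, even though the entering group has 0 hydrogen-bond donors and 4-hydroxyphenyl has 1. No supporting evidence bears on why this is so.

On these data alone, it remains open whether a group carrying an amine or a carboxylic acid would stand apart at this place. A small alkyl chain in place of the aromatic ring is equally untested by the compounds shown.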